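The source may report more compounds than this note shows. Statements on the series, on what has been measured and on what is new or still open speak of the compounds shown alone.

Working notes on the series.

Compound 1, `O=C(O)CCCSCCN1C(=O)SC[C@@H]1/C=C/[C@@H](O)Cc1ccccc1`, is the reference for this step. In an in vivo ADME assay on the whole organism for pharmacokinetics, with Rattus norvegicus as the target (a lower number here means that more of the compound stays in the plasma, a higher number that more of the compound sits outside the plasma), compound 1 gives 0.792 L/kg, which is the second highest of the three numbers in hand. Going by the values given here, its nearest neighbour is compound 3, `CCc1cccc(C[C@H](O)/C=C/[C@H]2CSC(=O)N2CCSCCCC(=O)O)c1`, which in this assay gives 0.538 L/kg; the single change from compound 1 to compound 3 is ethyl in place of hydrogen on an aromatic carbon, and it reads a 1.5-fold lower number from compound 1 to compound 3 (0.17 log units; within the scatter). Compound 2, `Cc1cccc(C[C@H](O)/C=C/[C@H]2CCC(=S)N2CCSCCCC(=O)O)c1`, differs from compound 1 in more than one place; in this assay compound 2 gives 1.76 L/kg, beyond the scatter of compound 1.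

The step to compound 4, `O=C(O)CCCSCCN1C(=O)SC[C@@H]1/C=C/[C@@H](O)Cc1cccc(C(F)(F)F)c1`, is trifluoromethyl in place of hydrogen on an aromatic carbon. Among the compounds with values here, the only measured step that bears on it is the one from compound 1 to compound 3, a substituent for hydrogen on the same aromatic carbon, which stayed within the scatter. On that basis no step beyond the scatter is expected for compound 4 in this assay; the expected step is a 1.1-fold lower number from compound 1 to compound 4 (0.04 log units; within the scatter). The estimate for compound 4 in this assay is 0.72 L/kg, with a range from 0.4 L/kg to 1.3 L/kg.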

Compound 4, volume of distribution at steady state: 0.512 L/kg
Estimate against measurement, compound 4: 1.4-fold (0.15 log units) above; low and high end bracket the measured number.
By their numbers in this assay, from the lowest: compounds 4, 3 and 1 (each within the scatter of the next); then compound 2.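

In this assay, trifluoromethyl on this aromatic carbon reads a 1.5-fold lower number from compound 1 to compound 4 (0.19 log units; within the scatter), and trifluoromethyl in place of ethyl reads a 1.1-fold lower number from compound 3 to compound 4 (0.02 log units; within the scatter), so the two substituents can now be compared directly at one position. Two different groups on this carbon therefore leave the number within the scatter of the unsubstituted phenyl of compound 1, and compound 3 and compound 4 cannot be told apart, so no order among the three can be drawn. No measurement in hand bears on why these steps stay this small.

From the compounds shown here alone, whether an amine, a carboxylic acid or a longer chain on this aromatic carbon would give a step beyond the scatter remains open. Compound 2 differs from the others in more than one place, so no single change can account for its number.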